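This account rests on a few compounds, and the source may have more. Where it says the series, first, only, none or still open, it means among the compounds named here.

In a functional assay on the whole organism with Rattus norvegicus as the target (a higher number here means that more compound is needed for the effect, a lower number that less compound is needed), compound 3 (`CCNCCNC(=O)c1cc(Cl)c(N)cc1OC`) gives > 30 mg/kg and that is a limit, not a number. Compound 4 (`CCN(CCNC(=O)c1cc(Cl)c(N)cc1OC)Cc1cccc(OC)c1`) puts 3-methoxybenzyl in place of hydrogen on an amine nitrogen. Two measured compounds already carry a group on that nitrogen: compound 1 (`CCN(CCNC(=O)c1cc(Cl)c(N)cc1OC)Cc1ccccc1`) gives 0.31 mg/kg with benzyl there and compound 2 (`CCN(CCNC(=O)c1cc(Cl)c(N)cc1OC)Cc1ccoc1`) gives 3 mg/kg with (furan-3-yl)methyl there. Swapping these groups for hydrogen gave an at least 96-fold higher number from compound 1 to compound 3 (1.98 log units; beyond the scatter) and an at least 10-fold higher number from compound 2 to compound 3 (1.00 log units; beyond the scatter) as the two steps. Compound 4 is closest to compound 1, so a large move to a lower number is expected, the reverse of the first step. The expected step is an at least 60-fold lower number from compound 3 to compound 4 (1.77 log units; beyond the scatter) in this assay as a whole. Compound 4 is estimated at 0.5 mg/kg (range 0.1 mg/kg to 2.5 mg/kg).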

Compound 4, dose for half-maximal effect: 1 mg/kg
For compound 4 the middle estimate is 2.0-fold (0.30 log units) below the measured one; measured number inside the range.
By their numbers in this assay, from the lowest: compound 1; then compound 4; then compound 2. At a limit, above all of these: compound 3.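

Compound 4 shows that a third group on this amine nitrogen also lowers the number in this assay, with an at least 30-fold lower number from compound 3 to compound 4 (1.47 log units; beyond the scatter). That step starts from a limit, not a number: the limit of > 30 mg/kg in this assay, at which 1 of the 4 values shown sits. Methoxy on the benzyl ring gives a 3.2-fold higher number from compound 1 to compound 4 (0.51 log units; beyond the scatter), so it does not match plain benzyl, yet the 3-methoxyphenyl still improves on furan-3-yl, with a 3.0-fold lower number from compound 2 to compound 4 (0.48 log units; beyond the scatter).

Going by these compounds, whether a fluoro or a hydroxyl in place of that methoxy would give a lower number stays open. So does the effect of a longer chain between the nitrogen and the ring.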